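The source may report more compounds than this note shows. Statements on the series, on what has been measured and on what is new or still open speak of the compounds shown alone.

Working notes on the series. The shared core is carried by compound 1 `CC(=O)OC[C@H]1O[C@@H](OC2=CC(=O)c3ccccc3C2=O)[C@H](OC(C)=O)[C@@H](OC(C)=O)[C@@H]1OC(C)=O` and compound 2 `CC(=O)OC[C@H]1O[C@H](OC2=CC(=O)c3ccccc3C2=O)[C@H](OC(C)=O)[C@@H](OC(C)=O)[C@@H]1OC(C)=O`. In a functional assay on MCF7 cells (Homo sapiens) for cytotoxicity, read by sulforhodamine B assay, with a stated time of 72 h (a lower number here means a stronger inhibitor, a higher number a weaker inhibitor), compound 1 gives 4760 nM, and in this assay compound 2 gives 3520 nM. Going by the values given here, compound 2 has the lowest of the two numbers so far, but its nearest neighbour is compound 1 and the step of a 1.4-fold lower number from compound 1 to compound 2 (0.13 log units; within the scatter) stays within the scatter, so no order between the two is claimed. That step rests on the fact that compounds 1 and 2 differ only in the configuration as drawn alone, and therefore says nothing about exchanging one group for another.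

Compound 3 `CC(=O)N[C@H]1[C@@H](OC2=CC(=O)c3ccccc3C2=O)O[C@H](COC(C)=O)[C@@H](OC(C)=O)[C@@H]1OC(C)=O` is not yet measured in this assay. Against compound 2 the change is acetamido in place of acetoxy on a saturated ring carbon. Among the compounds with values here, no measured step replaces one group with another at a saturated ring carbon; the only measured step is the configurational one, which is within the scatter and gives no lead on direction. The expectation is therefore a step of a 1.0-fold lower number from compound 2 to compound 3 (0.00 log units; within the scatter) that does not go beyond the scatter, with the uncertainty widened for lack of a precedent. Compound 3 is expected to give 3500 nM in this assay, with a range from 1500 nM to 9000 nM.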

Compound 3, half-maximal inhibitory concentration: 6590 nM
Beside the measured number, compound 3's estimate is 1.9-fold (0.27 log units) below it; measured number inside the range.
By their numbers in this assay, from the lowest: compounds 2, 1 and 3 (each within the scatter of the next).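

In this assay, going by these compounds alone, the only measured exchange of one group for another at this saturated ring carbon, next to the ring atom that bears a large group, gives a 1.9-fold higher number from compound 2 to compound 3 (0.27 log units; within the scatter) and so stays within the scatter. Acetamido brings a hydrogen-bond donor that acetoxy lacks, and at this position that difference does not carry the number beyond the scatter, so the position accepts this exchange without a readable loss or gain. The compounds shown offer no measured property that would give a cause for the size of this step.

From the compounds shown here alone, whether an amine, a carboxylic acid or a longer chain at this saturated ring carbon would move the number beyond the scatter stays open. Also open, going by these compounds, is whether acetamido would give a similar step with the other configuration at the stereocentre that separates compound 1 from compound 2.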